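Variation of the aryl oxygen substituent on the shared core

The source may hold more compounds than are shown below. What is called first, only, known or untested is meant among the compounds shown, and "the series" means these compounds.

Measured so far:
compound 1 `COc1ccc(-n2c(C)nc3c(NC(C4CC4)C4CC4)nc(C)nc32)cc1` — 19 nM
compound 2 `Cc1nc(NC(C2CC2)C2CC2)c2nc(C)n(-c3ccc(S(C)(=O)=O)cc3)c2n1` — 140 nM
compound 3 `Cc1nc(NC(C2CC2)C2CC2)c2nc(C)n(-c3ccc(OC(F)(F)F)cc3)c2n1` — 9 nM

In a functional assay on CHO cells for antagonist activity at corticotropin-releasing factor receptor 1 (Homo sapiens), read by cAMP accumulation (a higher number here means a weaker inhibitor, a lower number a stronger inhibitor), compound 3 gives 9 nM, the lowest of the three numbers. Its nearest neighbour is compound 1, a step of a 2.1-fold lower number from compound 1 to compound 3 (0.32 log units; beyond the scatter); the furthest is compound 2, a step of a 16-fold lower number from compound 2 to compound 3 (1.19 log units; beyond the scatter).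

Compound 4 `Cc1nc(NC(C2CC2)C2CC2)c2nc(C)n(-c3ccc(OC(F)F)cc3)c2n1` differs from compound 3 in one place: hydrogen in place of fluoro on a saturated chain carbon bound to two fluorine atoms and an oxygen on an aromatic ring. Within the data shown here, only the step from compound 1 to compound 3 bears on this directly, since it exchanged methyl for trifluoromethyl on the same oxygen and moved the number by a 2.1-fold lower number from compound 1 to compound 3 (0.32 log units; beyond the scatter), a modest shift. Difluoromethoxy lies between methoxy and trifluoromethoxy in the count of fluorine atoms, so compound 4 is expected to land between compound 1 and compound 3, probably closer to compound 3. The steps of a 7.4-fold higher number from compound 1 to compound 2 (0.87 log units; beyond the scatter) and a 16-fold lower number from compound 2 to compound 3 (1.19 log units; beyond the scatter) show that the substituent on the aromatic carbon can matter considerably, but methylsulfonyl is a different kind of group and does not inform this small change.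

The expected step is therefore slight, likely within the scatter or just beyond it, toward a higher number: a 1.3-fold higher number from compound 3 to compound 4 (0.12 log units; within the scatter). For compound 4 in this assay the estimate is 12 nM, within a range of 5 nM to 30 nM.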

Compound 4, inhibition constant: 5 nM
Beside the measured number, compound 4's estimate is 2.4-fold (0.38 log units) above it; the range from low to high includes it.
By their numbers in this assay, from the lowest: compounds 4 and 3 (each within the scatter of the next); then compound 1; then compound 2.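

In this assay, the step of a 1.8-fold lower number from compound 3 to compound 4 (0.26 log units; within the scatter) stays within the scatter, so trifluoromethoxy and difluoromethoxy cannot be told apart at this aromatic carbon, and the third fluorine is not needed to hold the number in this range. Against methoxy, difluoromethoxy gives a 3.8-fold lower number from compound 1 to compound 4 (0.58 log units; beyond the scatter), beyond the scatter, so the shift earlier seen only with trifluoromethyl on this oxygen also appears with difluoromethyl, while against methylsulfonyl the step of a 28-fold lower number from compound 2 to compound 4 (1.45 log units; beyond the scatter) is large, as it was for trifluoromethoxy. No measurement at hand accounts for any of these steps.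

From the compounds shown here alone, whether the shift from methoxy needs two fluorine atoms on the oxygen-bound carbon remains open, and monofluoromethoxy would be the missing member of this short sequence. Also open is how far this aromatic carbon tolerates other kinds of group, such as a longer ether chain like ethoxy, an amine or a carboxylic acid, since the compounds shown cover only methoxy, its two fluorinated forms and methylsulfonyl.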